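This account rests on a few compounds, and the source may have more. Where it says the series, first, only, none or still open, it means among the compounds named here.

Measured so far in a functional assay on A549 cells (Homo sapiens) for inhibition, read by MTT assay, with a stated time of 72 h; a higher number here means a weaker inhibitor, a lower number a stronger inhibitor:
- compound 1, `Nc1ncnc2c1c(-c1cnc3[nH]ccc3c1)nn2CCCCCCCCC(=O)NO`: 12300 nM
- compound 2, `Nc1ncnc2c1c(-c1cnc3[nH]ccc3c1)nn2CCCCC(=O)NO`: > 150000 nM
- compound 3, `Nc1nc2cc(-c3nn(CCCCCC(=O)NO)c4ncnc(N)c34)ccc2o1`: > 100000 nM

Compound 1 gives a number in this assay, 12300 nM. For compound 2 the assay reports only a limit, > 150000 nM. The change between them is hydroxycarbamoyl in place of 4-(hydroxycarbamoyl)butyl on a saturated chain carbon, four bonds along the chain from an aromatic nitrogen, and it gave an at least 12-fold higher number from compound 1 to compound 2 (1.08 log units; beyond the scatter); the step ends at the limit of > 150000 nM in this assay, at which 1 of the 3 values shown sits, so its true size is not known.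

Compound 3 carries a different core; the difference between the two cores is not broken down here. In this assay compound 3 too reaches only a limit, > 100000 nM, which is the limit of > 100000 nM in this assay, at which 1 of the 3 values shown sits.

Compound 4, `Nc1nc2cc(-c3nn(CC(=O)NO)c4ncnc(N)c34)ccc2o1`, is not yet measured. It differs from compound 3 by hydroxycarbamoyl in place of 4-(hydroxycarbamoyl)butyl on a saturated chain carbon bound to an aromatic nitrogen. This is the same kind of change as that from compound 1 to compound 2, but not the same: there the place was on a saturated chain carbon, four bonds along the chain from an aromatic nitrogen, whereas here it is on a saturated chain carbon bound to an aromatic nitrogen.

Since the earlier shortening weakened inhibition beyond the scatter, and compound 3 already sits at a limit, compound 4 is expected to remain at or beyond a limit in this assay. The estimated step is a step that the limit leaves unreadable from compound 3 to compound 4. Compound 4 is expected to give about 200000 nM, most likely somewhere from 100000 nM to 500000 nM.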

Compound 4, half-maximal inhibitory concentration: 27700 nM
Beside the measured number, compound 4's estimate is 7.2-fold (0.86 log units) above it; measured number below the stated range.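

In this assay, shortening the chain on the second core gave an at least 3.6-fold lower number from compound 3 to compound 4 (0.55 log units; beyond the scatter), so inhibition improved here, whereas the comparable change on the first core weakened it. The change therefore does not carry over from one core to the other, not even in direction: the same change on two cores in this assay, an at least 12-fold higher number (1.08 log units; beyond the scatter) from compound 1 to compound 2 and an at least 3.6-fold lower number (0.55 log units; beyond the scatter) from compound 3 to compound 4, at least 44-fold (1.64 log units) apart, beyond the scatter of two such steps
This does not show that the core alone sets the direction, since the two pairs also differ in where the change sits on the chain and in the chain they start from, and the step to compound 4 has no known true size, as compound 3 reaches only a limit: the limit of > 100000 nM in this assay, at which 1 of the 4 values shown sits.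

The compounds shown leave open whether the reversal follows the core or the chain length, which a chain as long as that of compound 1 on the core of compound 3, and a chain as short as that of compound 4 on the core of compound 1, could help to separate. They also leave open whether the hydroxycarbamoyl end itself is needed for the activity of compound 4, a question that a carboxylic acid in its place could address.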